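The source may report more compounds than this note shows. Statements on the series, on what has been measured and on what is new or still open speak of the compounds shown alone.

In a functional assay on L1210/0 cells (Mus musculus) for antiproliferative activity, read by trypan blue exclusion, with a stated time of 48 h (a lower number here means a stronger inhibitor, a higher number a weaker inhibitor), compound 1 `Nc1ncnc2c1ncn2C[C@H]1C=C[C@@H](CO)C1` gives > 200000 nM, which is a limit of the assay and not a number. Compound 2 `Nc1nc(Cl)c2ncn(C[C@@H]3C[C@H](CO)c4c(-c5ccccc5)nnc(-c5ccccc5)c43)c2n1` gives > 200000 nM, also a limit. Compound 3 `OC[C@@H]1C=C[C@H](Cn2cnc3c(O)ncnc32)C1` departs from compound 1 in one place, (hydroxy in place of amino on an aromatic carbon), with hydroxy in place of amino on an aromatic carbon. Among the measured compounds shown here, no measured step shows what this change does. No step beyond the scatter is expected in either direction, so the estimated a number no higher from compound 1 to compound 3 (the limit leaves the size open) stays small. Compound 3 is expected to read 200000 nM, within an estimated range from 100000 nM to 400000 nM.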

Compound 3, half-maximal inhibitory concentration: > 200000 nM
Compound 3 was reported as a limit; the forecaster's own chance of this, stated with the estimate: 85%; the middle value sits exactly at the limit.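

Compound 1 and compound 3 both stand at a limit of this assay, so no step can be read between them: the limit of > 200000 nM in this assay, at which 3 of the 3 values shown sit.

The compounds shown leave open what hydroxy in place of amino on an aromatic carbon does to antiproliferative activity.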